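The source may hold more compounds than are shown below. What is called first, only, known or untested is meant among the compounds shown, and "the series" means these compounds.

Three measured compounds and one unmeasured compound make up this set, and all of them were or are to be examined in a physicochemical assay for acid dissociation. Compound 1 `Cc1cc(C)cc(Cc2ccc3c(NCCCNCc4ccco4)ccnc3c2)c1` gives 9.47 in this assay. Compound 2 `c1coc(CNCCCNc2ccnc3cc(CC4CCCCC4)ccc23)c1` gives 9.47 in this assay; it differs from compound 1 by cyclohexyl in place of 3,5-dimethylphenyl on a saturated chain carbon bound to an aromatic carbon, and that structural change made the step of no change at the digits printed from compound 1 to compound 2 (within the scatter). Compound 3 `COc1ccc(F)cc1CNCCCNc1ccnc2cc(Cc3cc(C)cc(C)c3)ccc12` gives 9.47 in this assay, and the two values of compound 1 and compound 3 lie within the scatter of each other, as the step of no change at the digits printed from compound 1 to compound 3 (within the scatter) shows.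

Compound 4 `COc1ccc(F)cc1CNCCCNc1ccnc2cc(CC3CCCCC3)ccc12` remains to be measured in this assay. It stands to compound 3 as compound 2 stands to compound 1: the difference is cyclohexyl in place of 3,5-dimethylphenyl on a saturated chain carbon bound to an aromatic carbon, and the place of the change is described in the same words both times, so it is the same change made on another core. The two cores differ as 5-fluoro-2-methoxyphenyl in place of furan-2-yl on a saturated chain carbon bound to an amine nitrogen, the change that separates compound 1 from compound 3.

The step from compound 3 to compound 4 is expected to be no change at the digits printed from compound 3 to compound 4 (within the scatter), resting on compound 1 and compound 2, whose step no change at the digits printed from compound 1 to compound 2 (within the scatter) stayed within the scatter, and on compound 3, whose value 9.47 matched compound 1. Compound 4 is therefore estimated to give 9.47 in this assay, between 9.2 and 9.75.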

Compound 4, acid dissociation constant: 9.47
For compound 4 middle estimate and measured number coincide at the digits printed; the measured number falls inside the stated range.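

In this assay cyclohexyl in place of 3,5-dimethylphenyl on the core carrying 5-fluoro-2-methoxyphenyl gave no change at the digits printed from compound 3 to compound 4 (within the scatter) and so read the same as on the core carrying furan-2-yl, where the same change gave no change at the digits printed from compound 1 to compound 2 (within the scatter); the other change, 5-fluoro-2-methoxyphenyl in place of furan-2-yl, gave no change at the digits printed from compound 2 to compound 4 (within the scatter) and so closed a square of four compounds with no step beyond the scatter on any side. This shows that the cyclohexyl change carried from one core to the other with the same outcome, but that outcome is the absence of a step, so the square cannot show whether a real step would carry across in the same way, and two cores set no rule for the wider series. Nothing shown bears on why the four values stand level.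

The compounds shown leave open whether the values would stay level with a carboxylic acid or an additional amine on the group now held by cyclohexyl or 3,5-dimethylphenyl. They also leave open what a longer chain in place of the one carrying the two amine nitrogens would give in this assay on either core.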